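The source may report more compounds than this note shows. Statements on the series, on what has been measured and on what is new or still open speak of the compounds shown alone.

Working notes on the shared core of compound 2 `C=CC(=O)NCc1coc(-c2c(N)ncnc2Nc2ccc(Oc3ccccc3)c(Cl)c2)n1`. For the measured compounds named here, in an in vitro ADME assay on microsomes from liver (Rattus norvegicus) for metabolic stability, tested at 5 uM (on this read-out lower numbers stand for a shorter-lived compound and higher numbers for a longer-lived compound), compound 2 gives 0.983 h, the highest of the three numbers so far; compound 3 `C=CC(=O)NCc1coc(-c2c(N)ncnc2Nc2ccc(Oc3cc(Cl)ccc3Cl)c(Cl)c2)n1` gives 0.85 h, within the scatter of it, and compound 1 `C=CC(=O)NCc1coc(-c2c(N)ncnc2Nc2ccc(OCc3ccccn3)c(F)c2)n1` gives 0.267 h, beyond the scatter. Compound 4 `C=CC(=O)NCc1coc(-c2c(N)ncnc2Nc2ccc(Oc3cccc(F)c3)c(Cl)c2)n1` is not yet measured; it differs from compound 2 by fluoro in place of hydrogen on an aromatic carbon. Going by the values given here, the only measured step on the phenoxy group, a 1.2-fold lower number from compound 2 to compound 3 (0.06 log units; within the scatter), stayed within the scatter; no measured step with a single fluoro exists. In this assay a step within the scatter is therefore expected, a 1.1-fold lower number from compound 2 to compound 4 (0.04 log units; within the scatter). Compound 4 is estimated at 0.9 h, with a range from 0.45 h to 1.8 h.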

Compound 4, half-life: 0.9 h
Beside the measured number, compound 4's estimate shows no gap at the digits printed; the range from low to high includes it.
By their numbers in this assay, from the lowest: compound 1; then compounds 3, 4 and 2 (each within the scatter of the next).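

In this assay, fluoro in place of hydrogen on the phenoxy group gives a 1.1-fold lower number from compound 2 to compound 4 (0.04 log units; within the scatter) and adds a single-fluoro step to this position. Replacing 2,5-dichlorophenyl with 3-fluorophenyl gives a 1.1-fold higher number from compound 3 to compound 4 (0.02 log units; within the scatter), so the phenyl, 3-fluorophenyl and 2,5-dichlorophenyl groups on the oxygen are not separated by this read-out. Nothing measured here gives a reason for these small steps. Going by these compounds, whether an amine or a carboxylic acid on the same phenyl ring would give a step beyond the scatter remains open.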